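The source may hold more compounds than are shown below. What is called first, only, known or untested is meant among the compounds shown, and "the series" means these compounds.

Compound 1 `O=C(NCc1ccc(CNS(=O)(=O)c2ccccc2Cl)cc1)c1cccnc1` gives 100 nM in an assay on MDA-MB-231 cells for displacement of a labelled ligand from C-X-C chemokine receptor type 4 (Homo sapiens), read by fluorescence and microscopy, with stated times of 10 min and 30 min; a higher number here means that more compound is needed for the effect, a lower number that less compound is needed. Compound 2 `O=C(NCc1ccc(CNS(=O)(=O)c2cccc3ccccc23)cc1)c1cccnc1` carries naphthalen-1-yl in place of 2-chlorophenyl on a sulfonyl sulfur and gives 1000 nM, a step of a 10-fold higher number from compound 1 to compound 2 (1.00 log units; beyond the scatter). Compound 3 `Cc1ccccc1C(=O)NCc1ccc(CNS(=O)(=O)c2ccccc2Cl)cc1` differs from compound 1 by 2-methylphenyl in place of pyridin-3-yl on a carbonyl carbon; compound 3 gives 1000 nM, and the step of a 10-fold higher number from compound 1 to compound 3 (1.00 log units; beyond the scatter) is of like size. Compound 4 `Cc1ccccc1C(=O)NCc1ccc(CNS(=O)(=O)c2cccc3ccccc23)cc1` has not yet been measured in this assay. It differs from compound 3 by naphthalen-1-yl in place of 2-chlorophenyl on a sulfonyl sulfur, the same change as that made between compound 1 and compound 2, here placed on the core of compound 3 rather than the core of compound 1. Because a 10-fold higher number from compound 1 to compound 2 (1.00 log units; beyond the scatter) was a modest loss, a step of similar size is expected here, an 8.0-fold higher number from compound 3 to compound 4 (0.90 log units; beyond the scatter), though a single prior instance leaves the expectation loose. Compound 4 is therefore estimated at 8000 nM, with a range from 2000 nM to 30000 nM.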

Compound 4, effective concentration (reported as EC, without a stated level of effect): 100 nM
Estimate against measurement, compound 4: 80-fold (1.90 log units) above; the whole stated range lies above it.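

In this assay the change from 2-chlorophenyl to naphthalen-1-yl does not carry from one core to the other, and on the core of compound 3 it gives a 10-fold lower number from compound 3 to compound 4 (1.00 log units; beyond the scatter), opposite in direction to the earlier step: the same change on two cores in this assay, a 10-fold higher number (1.00 log units; beyond the scatter) from compound 1 to compound 2 and a 10-fold lower number (1.00 log units; beyond the scatter) from compound 3 to compound 4, 100-fold (2.00 log units) apart, beyond the scatter of two such steps. The change from pyridin-3-yl to 2-methylphenyl on a carbonyl carbon likewise reverses, giving a 10-fold lower number from compound 2 to compound 4 (1.00 log units; beyond the scatter): the same change on two cores in this assay, a 10-fold higher number (1.00 log units; beyond the scatter) from compound 1 to compound 3 and a 10-fold lower number (1.00 log units; beyond the scatter) from compound 2 to compound 4, 100-fold (2.00 log units) apart, beyond the scatter of two such steps. The two changes are therefore not independent in these four compounds, but the data do not show why, nor whether the same holds for other groups at these two places.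

Still open, from the compounds shown here alone, is how an unsubstituted phenyl on the sulfonyl sulfur would read on either core. Also open, going by these compounds, is how a carboxylic acid or a amine-bearing chain on the carbonyl carbon would read.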